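Tert-butyl ester of the ring-fused acid in compound 1

The source may hold more compounds than are shown below. What is called first, only, known or untested is meant among the compounds shown, and "the series" means these compounds.

Compound 1 `CC1(C)[C@@H]2CC3=N[C@@H](CCC(=O)O)C(=O)O[C@@]3(C)[C@H]1C2` and compound 2 `CC1(C)[C@H]2CC3=N[C@H](CCC(=O)O)C(=O)O[C@]3(C)[C@@H]1C2` share every atom and bond and differ only in configuration. In a functional assay on PC-3 cells (Homo sapiens) for antiproliferative activity, read by sulforhodamine B assay, with a stated time of 48 h (a higher number here means a weaker inhibitor, a lower number a stronger inhibitor), compound 1 gives 42000 nM, and compound 2 gives 38000 nM; the two stand at the same level, as the step of a 1.1-fold lower number from compound 1 to compound 2 (0.04 log units; within the scatter) shows. Within the data shown here, the mirror-image pair is the only measured step, and it carries no information on a change at the carboxylic acid (the fact that compounds 1 and 2 differ only in the configuration as drawn).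

Compound 3 `CC(C)(C)OC(=O)CC[C@@H]1N=C2C[C@@H]3C[C@@H](C3(C)C)[C@]2(C)OC1=O` carries tert-butyl in place of hydrogen on an oxygen next to a carbonyl group. Among the measured compounds shown here, no measured step involves the acid, so the expectation for compound 3 rests on the structural change alone, with nothing to anchor its direction or size beyond the level of compound 1. The working expectation is a modest change, a step of a 2.1-fold lower number from compound 1 to compound 3 (0.32 log units; beyond the scatter) in this assay, with wide uncertainty in both directions. Compound 3 is therefore estimated at 20000 nM in this assay, with a range from 5000 nM to 80000 nM.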

Compound 3, half-maximal inhibitory concentration: 42000 nM
Estimate against measurement, compound 3: 2.1-fold (0.32 log units) below; the measured number falls inside the stated range.
By their numbers in this assay, from the lowest: compounds 2, 1 and 3 (each within the scatter of the next).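

In this assay, the change from carboxy to tert-butoxycarbonyl gives no change at the digits printed from compound 1 to compound 3 (within the scatter). Among these compounds, this is the first measured step at the acid end of the series, which the mirror-image pair could not supply, and it shows that the hydrogen on this oxygen can give way to tert-butyl without the number leaving the scatter, so a free carboxy group is not needed to hold the level of compound 1 in this readout. Nothing in the data at hand bears on why the number holds across this change.

Among the compounds shown here, the position therefore has one flat step and no step that moves the number, so it remains open whether a methyl ester, a primary amide, an amine or a tetrazole in place of the carboxy group would stand at the same level, and whether a shorter or longer chain between the shared core and that group would shift it. From the compounds shown here alone, it also remains open whether the mirror image of compound 3 would match compound 3, as compound 2 matches compound 1.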